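This account rests on a few compounds, and the source may have more. Where it says the series, first, only, none or still open, it means among the compounds named here.

In a functional assay on HGC-27 cells (Homo sapiens) for antiproliferative activity, read by MTT assay, with stated times of 72 h and 4 h (a lower number here means a stronger inhibitor, a higher number a weaker inhibitor), compound 1 `COc1ncc(-c2cc3c(N4CCCCC4)ncnc3s2)cc1NS(=O)(=O)c1ccc(F)cc1F` gives 1200 nM and compound 2 `COc1ncc(-c2cc3c(N4CC(OC)C4)ncnc3s2)cc1NS(=O)(=O)c1ccc(F)cc1F` gives 830 nM. These two share one core, and placing 3-methoxyazetidin-1-yl in place of piperidin-1-yl is a 1.4-fold lower number from compound 1 to compound 2 (0.16 log units; within the scatter). Compound 3 `COc1ncc(-c2nc3c(N4CC(C)OC(C)C4)ncnc3s2)cc1NS(=O)(=O)c1ccc(F)cc1F` carries 2,6-dimethylmorpholin-4-yl on a different core and gives 270 nM, the lowest of the three numbers and beyond the scatter of both others. Both core and group differ in that comparison, so the data do not separate their shares in the gap.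

Compound 4 `COc1ncc(-c2nc3c(N4CC5CCCC5C4)ncnc3s2)cc1NS(=O)(=O)c1ccc(F)cc1F` keeps the core of compound 3 and changes only the group on an aromatic carbon: a group of 8 heavy atoms (7 carbon, 1 nitrogen; one five-membered non-aromatic ring of carbon only, one five-membered non-aromatic ring with 1 hetero atom) in place of a group of 8 heavy atoms (6 carbon, 1 nitrogen, 1 oxygen; one six-membered non-aromatic ring with 2 hetero atoms), on an aromatic carbon. Within the data shown here, no measured step makes this exchange, and none on the core of compound 3 tests any exchange of this group. Among the measured compounds shown here, the one measured step that swaps the group at this place, on the other core, is a 1.4-fold lower number from compound 1 to compound 2 (0.16 log units; within the scatter). That small step gives no ground for expecting a shift beyond the scatter in this assay, though it is only weak evidence and the range is kept wide. The expected change is a 1.1-fold higher number from compound 3 to compound 4 (0.05 log units; within the scatter), with no clear direction. Compound 4 is estimated at 300 nM, with an expected range of 110 nM to 850 nM.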

Compound 4, half-maximal inhibitory concentration: 310 nM
Estimate against measurement, compound 4: 1.0-fold (0.01 log units) below; the measured number falls inside the stated range.
By their numbers in this assay, from the lowest: compounds 3 and 4 (each within the scatter of the next); then compounds 2 and 1 (each within the scatter of the next).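

On the core of compound 3, the exchange of 2,6-dimethylmorpholin-4-yl for the group built from two fused five-membered rings gives, in this assay, a 1.1-fold higher number from compound 3 to compound 4 (0.06 log units; within the scatter), and this is the only step shown on that core. It shows that on this core the ring oxygen and the six-membered ring of the leaving group can be given up without a shift beyond the scatter, something the earlier step on the other core could not show; with a 1.4-fold lower number from compound 1 to compound 2 (0.16 log units; within the scatter), both exchanges at this place, one on each core, now lie within the scatter, and no compound shown goes against that. No measurement offered here speaks to the reason for this result.

The share of the core in the gap between compound 2 and compound 3 stays open, since each group shown stands on one core only. Also open, going by these compounds, is whether a group of another kind at this place, such as a primary amine or a piperidine bearing a carboxylic acid, would move the number beyond the scatter on either core.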